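A Pyridinyl Swap Among Weak Trypsin Binders

This account rests on a few compounds, and the source may have more. Where it says the series, first, only, none or still open, it means among the compounds named here.

Of the compounds shown here, two have so far been tested in an assay on isolated protein for inhibition of Trypsin (Homo sapiens); on this read-out higher numbers stand for weaker inhibition and lower numbers for stronger inhibition. Compound 1 `Nc1noc2ccc(-n3nc(C(F)(F)F)c4ccc(-c5ccc(N6CCCCC6=O)cc5F)c(F)c43)cc12` gives > 10000 nM in this assay, which is a limit of the assay rather than a number. Compound 2 `CN(C)Cc1nccn1-c1ccc(-c2ccc3c(C(N)=O)nn(-c4ccc5onc(N)c5c4)c3c2F)c(F)c1` likewise gives > 10000 nM in this assay, again only a limit. Both results sit at the limit of > 10000 nM in this assay, at which 2 of the 2 values shown sit, so compound 2 stands at the same limit as the one other measured compound, and nothing separates the two on the numbers shown. Compound 3 `CN(C)Cc1ncccc1-c1ccc(-c2ccc3c(C(N)=O)nn(-c4ccc5onc(N)c5c4)c3c2F)c(F)c1` has not yet been measured in this assay. It differs from compound 2 in one place: 2-((dimethylamino)methyl)pyridin-3-yl in place of 2-((dimethylamino)methyl)-1H-imidazol-1-yl on an aromatic carbon. For the measured compounds named here, no measured pair shows what such a change does in this assay. With compound 1 and compound 2 both resting at the limit of > 10000 nM in this assay, at which 2 of the 2 values shown sit, the expected step that the limit leaves unreadable from compound 2 to compound 3 is no shift beyond the scatter, in either direction. Compound 3 is accordingly estimated at 15000 nM in this assay, within a range of 5000 nM to 50000 nM, most probably reported once more as a limit only.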

Compound 3, inhibition constant: > 10000 nM
Compound 3: only a limit was reported; the forecaster's own chance of this, stated with the estimate: 80%; the middle value lies beyond the limit too.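

In this assay compound 3 gives > 10000 nM, which is a limit of the assay and not a number. No step can be read from compound 2 to compound 3, as all the compounds rest at one limit: the limit of > 10000 nM in this assay, at which 3 of the 3 values shown sit. The compounds shown leave open whether 2-((dimethylamino)methyl)pyridin-3-yl in place of 2-((dimethylamino)methyl)-1H-imidazol-1-yl changes inhibition at all.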